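Branching the Chain on the Ring Nitrogen

The source may hold more compounds than are shown below. What is called first, only, known or untested is meant among the compounds shown, and "the series" means these compounds.

Measured compounds:
compound 1 `CCC(CC)CNC(=O)c1ccc2c(c1)c(Cc1ccc(C(=O)NS(=O)(=O)c3ccccc3C)cc1OC)cn2CC` – 1 nM
compound 2 `CCCn1cc(Cc2ccc(C(=O)NS(=O)(=O)c3ccccc3C)cc2OC)c2cc(C(=O)NCC(CC)CC)ccc21` – 0.794 nM

In an assay on lung parenchyma for binding affinity to cysteinyl leukotriene receptor 1 (Cavia porcellus), read by radioligand binding (a lower number here means a stronger inhibitor, a higher number a weaker inhibitor), compound 2 gives 0.794 nM, the lowest of the two numbers, yet the step of a 1.3-fold lower number from compound 1 to compound 2 (0.10 log units; within the scatter) lies within the scatter, so the two compounds cannot be ranked. Compound 3 `CCC(CC)CNC(=O)c1ccc2c(c1)c(Cc1ccc(C(=O)NS(=O)(=O)c3ccccc3C)cc1OC)cn2C(C)C` differs from compound 2 by isopropyl in place of propyl on an aromatic nitrogen. Among the compounds with values here, the only step that bears on this change is the lengthening from compound 1 to compound 2, which stayed within the scatter. No change beyond the scatter is therefore expected in this assay for compound 3. Compound 3 is estimated at 1 nM, within 0.4 nM to 2.5 nM, a step of a 1.3-fold higher number from compound 2 to compound 3 (0.10 log units; within the scatter).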

Compound 3, inhibition constant: 0.501 nM
Compound 3: middle estimate off by 2.0-fold (0.30 log units), on the high side, and the stated range covers the measured number.
By their numbers in this assay, from the lowest: compounds 3, 2 and 1 (each within the scatter of the next).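

Branching at this position costs no measurable binding in this assay: moving from the straight propyl to the isopropyl on the aromatic nitrogen gives a 1.6-fold lower number from compound 2 to compound 3 (0.20 log units; within the scatter). Adding a methyl to the chain carbon bound to that nitrogen also stays level, with a 2.0-fold lower number from compound 1 to compound 3 (0.30 log units; within the scatter), so straight and branched chains of these sizes cannot be told apart here. No supporting measurement bears on this result. Still open, on these data alone, is whether a larger group on this nitrogen, such as a cyclohexyl ring or a longer chain ending in an amine, would keep this binding.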